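This account rests on a few compounds, and the source may have more. Where it says the series, first, only, none or still open, it means among the compounds named here.

Compound 2 `CN1CCC(c2ccc3c(c2)oc(=O)n3C(=O)NCCCCc2ccccc2)CC1=O` is one of two compounds with a number in an assay on HEK293 cells for inhibition of acid ceramidase (Homo sapiens), read by fluorescence, with stated times of 10 min and 3 h; on this read-out higher numbers stand for weaker inhibition and lower numbers for stronger inhibition; in this assay compound 2 gives 105 nM. Its companion, compound 1 `CC(=O)N1CCC(c2ccc3c(c2)oc(=O)n3C(=O)NCCCCc2ccccc2)CC1`, gives 64 nM in this assay, and the step of a 1.6-fold higher number from compound 1 to compound 2 (0.22 log units; within the scatter) leaves the pair indistinguishable. Compound 3 `CC(C)CN1CCC(c2ccc3c(c2)oc(=O)n3C(=O)NCCCCc2ccccc2)CC1` differs from compound 2 by 1-isobutylpiperidin-4-yl in place of 1-methyl-2-oxopiperidin-4-yl on an aromatic carbon. No measured step exchanges these two groups; the only step shown, a 1.6-fold higher number from compound 1 to compound 2 (0.22 log units; within the scatter), stayed within the scatter, so no shift beyond the scatter is expected, and the estimated step of a 1.1-fold lower number from compound 2 to compound 3 (0.02 log units; within the scatter) reflects that. Compound 3 is therefore expected to give about 100 nM in this assay, between 30 nM and 400 nM.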

Compound 3, half-maximal inhibitory concentration: 120 nM
For compound 3 the middle estimate is 1.2-fold (0.08 log units) below the measured one, and the stated range covers the measured number.
By their numbers in this assay, from the lowest: compounds 1, 2 and 3 (each within the scatter of the next).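

In this assay the group on this aromatic carbon can lose its carbonyl altogether: a 1.1-fold higher number from compound 2 to compound 3 (0.06 log units; within the scatter) and a 1.9-fold higher number from compound 1 to compound 3 (0.27 log units; within the scatter) both stay within the scatter. Acetyl on the ring nitrogen, the carbonyl inside the ring and isobutyl on the ring nitrogen therefore cannot be told apart at this position. Nothing available bears on why this is so.

Still open, as far as these compounds go, is whether an unsubstituted ring amine, a carboxylic acid or a longer chain on that nitrogen would give a step beyond the scatter.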